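The source may report more compounds than this note shows. Statements on the series, on what has been measured and on what is new or still open speak of the compounds shown alone.

Measured so far in a functional assay on RAW264.7 cells (Mus musculus) for inhibition; a lower number here means a stronger inhibitor, a higher number a weaker inhibitor: compound 1 `O=C1/C(=C/c2ccccc2Cl)CCc2c(O)cccc21` gives 1280 nM. Compound 2 `O=C1/C(=C/c2ccccn2)CCc2cc(O)ccc21` gives only a limit of the assay, > 10000 nM. Compound 3 `O=C1/C(=C/c2cccc(Cl)c2)CCc2ccc(O)cc21` gives 210 nM.

Among these, compound 3 stands with the lowest of the two numbers that the assay returned. Compound 1 sits higher, and the gap between compound 3 and compound 1 lies beyond the usual scatter of repeated measurements. Compound 2 sits at the limit of > 10000 nM in this assay, at which 1 of the 3 values shown sits, so it offers no number to compare.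

Compound 4 `O=C1/C(=C/c2cccc(O)c2)CCc2ccc(O)cc21` is not yet measured. It differs from compound 3 in one place: hydroxy in place of chloro on an aromatic carbon. No measured pair among the compounds shown follows this same exchange, so the size of the step can only be anticipated. The expectation is that compound 4 gives a weaker inhibition than compound 3, with a step from compound 3 to compound 4 of a 3.8-fold higher number from compound 3 to compound 4 (0.58 log units; beyond the scatter) in this assay, larger than the scatter. The estimate for compound 4 is therefore 800 nM, expected to fall between 250 nM and 2500 nM.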

Compound 4, half-maximal inhibitory concentration: 810 nM
The estimate for compound 4 lay 1.0-fold (0.01 log units) below the measured number; the range from low to high includes it.
By their numbers in this assay, from the lowest: compound 3; then compounds 4 and 1 (each within the scatter of the next). At a limit, above all of these: compound 2.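

This is the first comparison among the compounds shown that changes only one place: in this assay, hydroxy in place of chloro on an aromatic carbon, meta to a large group, gives a 3.9-fold higher number from compound 3 to compound 4 (0.59 log units; beyond the scatter) and so weakens inhibition by more than the scatter. The two groups are therefore not interchangeable at this place on the six-membered aromatic ring, and of this pair compound 3, with chloro, is the stronger inhibitor. Nothing shown here gives a measured reason for this step.

From the compounds shown here alone, whether a methoxy, an amine or a carboxylic acid at this place would fall nearer to chloro or to hydroxy remains open. So does whether the same exchange would give a step of similar size at another place on that ring.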